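The source may hold more compounds than are shown below. What is called first, only, known or untested is meant among the compounds shown, and "the series" means these compounds.

Values so far in a functional assay on DU-145 cells (Homo sapiens) for inhibition, read by trypan blue exclusion, with a stated time of 96 h; on this read-out higher numbers stand for weaker inhibition of growth and lower numbers for stronger inhibition of growth:
- compound 1 `O=C(/C(=C\c1ccc(Cl)cc1)S(=O)(=O)c1ccc(Br)cc1)c1ccc(Br)cc1` gives 50000 nM
- compound 2 `COc1ccc(/C=C(\C(=O)c2ccc(Br)cc2)S(=O)(=O)c2ccc(Br)cc2)cc1` gives 25000 nM
- compound 3 `O=C(/C(=C\c1ccc(Cl)c([N+](=O)[O-])c1)S(=O)(=O)c1ccc(Br)cc1)c1ccc(Br)cc1` gives 10000 nM

Compound 3 stands lowest of the three at 10000 nM on these numbers, with a 2.5-fold lower number from compound 2 to compound 3 (0.40 log units; beyond the scatter) and a 5.0-fold lower number from compound 1 to compound 3 (0.70 log units; beyond the scatter) as its measured steps.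

Compound 4 `O=C(/C(=C\c1ccc(Cl)c([N+](=O)[O-])c1)Sc1ccc(Br)cc1)c1ccc(Br)cc1` has (4-bromophenyl)sulfanyl in place of (4-bromophenyl)sulfonyl on a double-bonded chain carbon bound to a carbonyl carbon and a double-bonded chain carbon, which amounts to (4-bromophenyl)sulfanyl in place of (4-bromophenyl)sulfonyl on a double-bonded chain carbon bound to a carbonyl carbon and a double-bonded chain carbon in full.

Within the data shown here, no measured step touches this group. All three change another part of the molecule, so they serve only as a gauge of step size in the series, from a 2.0-fold lower number from compound 1 to compound 2 (0.30 log units; within the scatter) up to a 5.0-fold lower number from compound 1 to compound 3 (0.70 log units; beyond the scatter) at the largest. A step of similar modest size is therefore expected in this assay, towards a higher number. Among the measured compounds shown here, no measured pair tests that direction, so it is held loosely.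

The expected step is a 2.0-fold higher number from compound 3 to compound 4 (0.30 log units; within the scatter) on this reasoning. For compound 4 the estimated value is 20000 nM and the expected range runs from 5000 nM to 80000 nM at this stage.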

Compound 4, concentration for 50% growth inhibition: 10000 nM
Compound 4: middle estimate off by 2.0-fold (0.30 log units), on the high side, within the range that was stated.
By their numbers in this assay, from the lowest: compounds 3 and 4 (each within the scatter of the next); then compounds 2 and 1 (each within the scatter of the next).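

In this assay, among these compounds, the first measured change at this position, (4-bromophenyl)sulfanyl in place of (4-bromophenyl)sulfonyl on a double-bonded chain carbon bound to a carbonyl carbon and a double-bonded chain carbon, gives no change at the digits printed from compound 3 to compound 4 (within the scatter) and so places the pair level on this read-out. With the 4-chloro-3-nitrophenyl group held constant, the entering group carries 8 heavy atoms, fewer than the group that leaves, and 1 hydrogen-bond acceptor against 2, without a step beyond the scatter. No available evidence bears on why the two groups read alike.

As far as these compounds go, whether the same exchange stays level on the 4-chlorophenyl and 4-methoxyphenyl members remains open. Also open, from the compounds shown here alone, is how a sulfinyl group or a methylene linker would read in this place, and whether either would depart from the level pair.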